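One Group Swapped on Compound 3

The source may hold more compounds than are shown below. What is called first, only, known or untested is meant among the compounds shown, and "the series" means these compounds.

Of the compounds shown here, three sharing one core have been tested in an assay on HEK293 cells for inhibition of Voltage-dependent T-type calcium channel subunit alpha-1G (Homo sapiens), read by patch clamp; a higher number here means a weaker inhibitor, a lower number a stronger inhibitor. Compound 1 `CCCc1nc(-c2ccccc2)c(CNCCN2CCN(c3ccc(Cl)cc3)CC2)o1` gives 2820 nM, compound 2 `CCCc1nc(-c2ccccc2)c(CNCCN2CCN(c3ccccc3)CC2)o1` gives 10300 nM, and compound 3 `CCCc1nc(-c2ccccc2)c(CNCCN2CCN(c3ccccc3C)CC2)o1` gives 4300 nM, which places compound 3 second highest of the three, close to compound 1 yet clearly apart from compound 2. Compound 4 `CCCc1nc(-c2ccccc2)c(CNCCN2CCN(c3cccc(Cl)c3)CC2)o1` differs from compound 3 in one place: 3-chlorophenyl in place of 2-methylphenyl on an amine nitrogen in a ring. For the measured compounds named here, two measured steps bear on this change. Removing chloro gave a 3.7-fold higher number from compound 1 to compound 2 (0.56 log units; beyond the scatter), adding methyl gave a 2.4-fold lower number from compound 2 to compound 3 (0.38 log units; beyond the scatter), and a 1.5-fold higher number from compound 1 to compound 3 (0.18 log units; within the scatter). Compound 4 is expected to sit near compound 3 because compound 1 gives 2820 nM while carrying chloro. The step of a 1.3-fold lower number from compound 3 to compound 4 (0.13 log units; within the scatter) is therefore expected to stay within the scatter. Compound 4 is estimated at 3200 nM, within 1300 nM to 8000 nM.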

Compound 4, half-maximal inhibitory concentration: 1450 nM
Compound 4: middle estimate off by 2.2-fold (0.34 log units), on the high side, and the stated range covers the measured number.
By their numbers in this assay, from the lowest: compounds 4, 1 and 3 (each within the scatter of the next, the first and the last beyond it); then compound 2.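

In this assay, 3-chlorophenyl in place of 2-methylphenyl gives a 3.0-fold lower number from compound 3 to compound 4 (0.47 log units; beyond the scatter) and so separates two groups on this nitrogen by more than the scatter, which 4-chlorophenyl and 2-methylphenyl did not do. Chloro added to the plain phenyl gives a 7.1-fold lower number from compound 2 to compound 4 (0.85 log units; beyond the scatter) and is the largest step in this set. By contrast, 3-chlorophenyl in place of 4-chlorophenyl gives a 1.9-fold lower number from compound 1 to compound 4 (0.29 log units; within the scatter) and stays within the scatter, so these two chlorophenyl groups cannot be told apart.

Nothing available gives a cause for these steps. From the compounds shown here alone, how 3-bromophenyl or 3-methoxyphenyl would compare with 3-chlorophenyl on this nitrogen stays open.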